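The source may hold more compounds than are shown below. What is called first, only, known or untested is meant among the compounds shown, and "the series" means these compounds.

Working notes on the series. Compound 1, `Clc1cccc(-c2nnc[nH]2)c1`, and compound 2, `Oc1ccccc1-c1nnc[nH]1`, share the same core and carry one substituent each on the six-membered ring. In an assay on cells for inhibition of Indoleamine 2,3-dioxygenase 1 (Homo sapiens), read by HPLC, with a stated time of 20 min (on this read-out lower numbers stand for stronger inhibition and higher numbers for weaker inhibition), compound 1 gives 31000 nM, and compound 2 gives 31000 nM in the same assay. Compound 2 thus stands level with compound 1 at the digits shown, its nearest neighbour, with no change between the two beyond the scatter, so neither ordering of the pair is supported by the numbers.

Compound 3, `Oc1ccc(Cl)cc1-c1nnc[nH]1`, combines both substituents. Relative to compound 2 the difference is chloro in place of hydrogen on an aromatic carbon, with the chloro entering para to a hydroxy group. For the measured compounds named here, no measured step of this kind exists. The two single substituents each give the same weak value, so a step of modest size at most is expected here, leaning toward somewhat stronger inhibition, but one that could well remain within the scatter. For compound 3 the expected step in this assay is a 2.1-fold lower number from compound 2 to compound 3 (0.32 log units; beyond the scatter). Compound 3 is therefore estimated at 15000 nM, with a range from 5000 nM to 45000 nM.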

Compound 3, half-maximal inhibitory concentration: 600 nM
Estimate against measurement, compound 3: 25-fold (1.40 log units) above; the whole stated range lies above it.
By their numbers in this assay, from the lowest: compound 3; then compounds 1 and 2 (each within the scatter of the next).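

Reading the series in this assay, chloro in place of hydrogen on an aromatic carbon, para to a hydroxy group, gives a 52-fold lower number from compound 2 to compound 3 (1.71 log units; beyond the scatter) and the entry of the hydroxy group gives a 52-fold lower number from compound 1 to compound 3 (1.71 log units; beyond the scatter), so both single changes are large and beyond the scatter once the other group is present. Compounds 1 and 2 did not show this: each carries one of the two groups and the pair stands level, whereas the steps to compound 3 show that this chloro and this hydroxy group together go with much stronger inhibition than either group alone. Nothing shown here accounts for the size of these steps.

The compounds shown leave open whether chloro is specifically required at this place, or whether fluoro, bromo or methyl para to the hydroxy group would give a comparable step. They also leave open whether the hydroxy group could give way to an amine or a methoxy group with the chloro kept in place.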